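This account rests on a few compounds, and the source may have more. Where it says the series, first, only, none or still open, it means among the compounds named here.

Working notes on the series, read in a functional assay on DU-145 cells (Homo sapiens) for cytotoxicity, read by MTT assay; on this read-out lower numbers stand for stronger inhibition and higher numbers for weaker inhibition: compound 1 (`CCC(O)CO[C@H](CC=C(C)C)C1=CC(=O)c2c(O)ccc(O)c2C1=O`) gives 16400 nM and compound 2 (`CC(C)=CC[C@@H](OC(=O)C1CCCCO1)C1=CC(=O)c2c(O)ccc(O)c2C1=O`) gives 24700 nM in this assay. Compound 3 (`CC(C)=CC[C@@H](OC(=O)CC(C)(O)c1ccccc1)C1=CC(=O)c2c(O)ccc(O)c2C1=O`) gives > 100000 nM as a limit and not a number. The change to compound 4 (`CCC(O)(CC)CC(=O)O[C@H](CC=C(C)C)C1=CC(=O)c2c(O)ccc(O)c2C1=O`) is 1-ethyl-1-hydroxypropyl in place of 1-hydroxy-1-phenylethyl on a saturated chain carbon bound to a carbonyl carbon and removes the six-membered aromatic ring. Within the data shown here, the step of an at least 4.0-fold higher number from compound 2 to compound 3 (0.60 log units; beyond the scatter) is the one measured step beyond the scatter and it brought that ring in, whereas a 1.5-fold higher number from compound 1 to compound 2 (0.18 log units; within the scatter) stays within the scatter. A return towards compound 2 at 24700 nM is therefore expected. The estimated step of an at least 2.8-fold lower number from compound 3 to compound 4 (0.45 log units; beyond the scatter) is a modest one towards a lower number. Compound 4 is estimated at 35000 nM in this assay with an expected range of 12000 nM to 100000 nM for now.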

Compound 4, half-maximal inhibitory concentration: 67000 nM
The estimate for compound 4 lay 1.9-fold (0.28 log units) below the measured number; the measured number falls inside the stated range.
By their numbers in this assay, from the lowest: compounds 1 and 2 (each within the scatter of the next); then compound 4. At a limit, above all of these: compound 3.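

With 1-ethyl-1-hydroxypropyl in place of 1-hydroxy-1-phenylethyl, the change gives an at least 1.4-fold lower number from compound 3 to compound 4 (0.17 log units; that floor lies within the scatter) and yields a measured number without the six-membered aromatic ring, although that floor establishes no gain beyond the scatter. The ring-free ester still does not return to the earlier values, with a 2.7-fold higher number from compound 2 to compound 4 (0.43 log units; beyond the scatter) and a 4.1-fold higher number from compound 1 to compound 4 (0.61 log units; beyond the scatter) on record. Compound 3 remains a limit and not a number: the limit of > 100000 nM in this assay, at which 1 of the 4 values shown sits.

The true size of the step out of compound 3 stays unresolved. On these data alone, whether an amine, a carboxylic acid or a longer chain at this place would approach compound 2 also stays open.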